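Methyl on the sulfonyl aryl: a repeated single-atom step

The compounds below may be only part of what the source reports. "The series", "measured", "known", "first", "only" and "open" are said of these compounds alone.

Compound 1 `Cc1ccc(S(=O)(=O)NCc2ccc(CNC(=O)c3ccc([N+](=O)[O-])cc3)cc2)cc1`, compound 2 `O=C(NCc1ccc(CNS(=O)(=O)c2ccccc2)cc1)c1ccc([N+](=O)[O-])cc1` and compound 3 `O=C(NCc1ccc(CNS(=O)(=O)c2ccccc2)cc1)c1ccccc1F` have been measured in an assay on MDA-MB-231 cells for binding affinity to C-X-C chemokine receptor type 4 (Homo sapiens), read by immunofluorescence and microscopy, with stated times of 10 min and 30 min; on this read-out higher numbers stand for an effect only at larger amounts of compound and lower numbers for an effect already at smaller amounts. Compound 1 gives 10 nM, compound 2 gives 100 nM and compound 3 gives 1000 nM, so compound 3 carries the highest number of the three, with both of its steps beyond the scatter.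

The difference between compound 2 and compound 1 is methyl in place of hydrogen on an aromatic carbon, and it made a 10-fold lower number from compound 2 to compound 1 (1.00 log units; beyond the scatter). The cores of compound 2 and compound 3 differ by 2-fluorophenyl in place of 4-nitrophenyl on a carbonyl carbon, which made a 10-fold higher number from compound 2 to compound 3 (1.00 log units; beyond the scatter).

Compound 4 `Cc1ccc(S(=O)(=O)NCc2ccc(CNC(=O)c3ccccc3F)cc2)cc1` is not yet measured. It differs from compound 3 by methyl in place of hydrogen on an aromatic carbon, the same change as between compound 2 and compound 1 and at the same kind of place. One measured example of this change exists, so the expectation rests on it alone: in this assay the expected step is a 10-fold lower number from compound 3 to compound 4 (1.00 log units; beyond the scatter), because a 10-fold lower number from compound 2 to compound 1 (1.00 log units; beyond the scatter) on the other core. Compound 4 is therefore estimated at 100 nM, with a likely range from 30 nM to 400 nM.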

Compound 4, effective concentration (reported as EC, without a stated level of effect): 1000 nM
Compound 4: middle estimate off by 10-fold (1.00 log units), on the low side, and the stated range ends below it.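

On the core of compound 3, methyl in place of hydrogen on an aromatic carbon gives no change at the digits printed from compound 3 to compound 4 (within the scatter) in this assay, so this change does not carry over from the core of compound 2: the same change on two cores in this assay, a 10-fold lower number (1.00 log units; beyond the scatter) from compound 2 to compound 1 and no change at the digits printed (within the scatter) from compound 3 to compound 4, 10-fold (1.00 log units) apart, beyond the scatter of two such steps

Read the other way, 2-fluorophenyl in place of 4-nitrophenyl on a carbonyl carbon gives a 100-fold higher number from compound 1 to compound 4 (2.00 log units; beyond the scatter), and the size of this step depends on whether the methyl is present: the same change on two cores in this assay, a 10-fold higher number (1.00 log units; beyond the scatter) from compound 2 to compound 3 and a 100-fold higher number (2.00 log units; beyond the scatter) from compound 1 to compound 4, 10-fold (1.00 log units) apart, beyond the scatter of two such steps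

Among these compounds, the two changes therefore do not add up across these four compounds, but with a single pair on each core this shows only that the methyl step differs with the group on the carbonyl, not why it differs or how general the difference is.

Open, on these data alone, is whether the lower number with methyl appears only with 4-nitrophenyl on the carbonyl carbon or also with other aryl groups, such as a phenyl carrying a nitrile or an amine. Also open, as far as these compounds go, is how an ethyl or methoxy group would behave in place of the methyl on either core.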